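The compounds below may be only part of what the source reports. "The series", "measured", "known", "first", "only" and "open" are said of these compounds alone.

Measured so far:
compound 1 `CC(C)(C)c1ccc(-c2cc(N3CCC(CCNS(N)(=O)=O)CC3)ncn2)cc1` — 10300 nM
compound 2 `NS(=O)(=O)NCCC1CCN(c2cc(-c3ccc(Cl)cc3)ncn2)CC1` — 30500 nM

In a functional assay on HT-29 cells (Homo sapiens) for antiproliferative activity, read by sulforhodamine B assay, with a stated time of 48 h (a higher number here means a weaker inhibitor of growth, a lower number a stronger inhibitor of growth), compound 2 stands highest of the two numbers, with compound 1 nearest at a 3.0-fold higher number from compound 1 to compound 2 (0.47 log units; beyond the scatter). Compound 3 `CCOC(=O)c1ccc(-c2cc(N3CCC(CCNS(N)(=O)=O)CC3)ncn2)cc1` carries ethoxycarbonyl in place of chloro on an aromatic carbon. Among the compounds with values here, the only step that bears on this position is the one from tert-butyl to chloro, a 3.0-fold higher number from compound 1 to compound 2 (0.47 log units; beyond the scatter), so only a loose guide exists for ethoxycarbonyl. Compound 3 is therefore expected to move a 2.0-fold lower number from compound 2 to compound 3 (0.31 log units; beyond the scatter), a small change toward the lower number of compound 1. The estimate for compound 3 in this assay is 15000 nM, with a range from 5000 nM to 45000 nM.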

Compound 3, concentration for 50% growth inhibition: 6800 nM
Compound 3: middle estimate off by 2.2-fold (0.34 log units), on the high side; measured number inside the range.
By their numbers in this assay, from the lowest: compounds 3 and 1 (each within the scatter of the next); then compound 2.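

In this assay, ethoxycarbonyl in place of chloro gives a 4.5-fold lower number from compound 2 to compound 3 (0.65 log units; beyond the scatter), so this position can recover what the change from tert-butyl to chloro lost. Ethoxycarbonyl in place of tert-butyl gives a 1.5-fold lower number from compound 1 to compound 3 (0.18 log units; within the scatter): two quite different groups cannot be told apart here, and among these three compounds only chloro stands apart. Nothing available accounts for this. From the compounds shown here alone, whether a carboxylic acid, an amine or a longer ester chain on this aromatic carbon would stay level with compound 1 and compound 3 or move toward compound 2 remains open.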